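Ester to Acid, Then Methoxy to Fluoro

A few compounds are considered here, and "the series" means these few. Any claim that something is new, unique, unknown or untested is made for them only; others in the source may bear on it.

In a functional assay, with a stated time of 150 min, tested at 5 ug/mL (on this read-out lower numbers stand for a weaker effect and higher numbers for a stronger effect at the one concentration tested), three compounds sharing one core have been measured. Compound 1 `COC(=O)c1c(Nc2ccc(OC)cc2)sc(C(=O)c2ccc(OC)cc2)c1C` gives 4.29%, compound 2 `COC(=O)c1c(Nc2ccc(F)cc2)sc(C(=O)c2ccc(OC)cc2)c1C` gives 5.28%, and compound 3 `COc1ccc(Nc2sc(C(=O)c3ccc(OC)cc3)c(C)c2C(=O)O)cc1` gives 20.2%, the highest of the three. The change between compound 1 and compound 2 is fluoro in place of methoxy on an aromatic carbon, with a step of a number 1 percentage points higher from compound 1 to compound 2 (within the scatter). Compound 3 differs from compound 1 by hydrogen in place of methyl on an oxygen next to a carbonyl group, and that step is a number 15.9 percentage points higher from compound 1 to compound 3 (beyond the scatter). Compound 4 `COc1ccc(C(=O)c2sc(Nc3ccc(F)cc3)c(C(=O)O)c2C)cc1` awaits measurement; it differs from compound 3 by fluoro in place of methoxy on an aromatic carbon, the same change as between compound 1 and compound 2, occurring twice among these compounds. Since the earlier step in this assay was a number 1 percentage points higher from compound 1 to compound 2 (within the scatter), a similar step is expected here: a number 0.8 percentage points higher from compound 3 to compound 4 (within the scatter). Compound 4 is therefore estimated at 21%, expected to lie between 10% and 32%.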

Compound 4, a percentage reported as activity, at one concentration (the size of the read-out at that concentration, not a potency): 0.1%
Beside the measured number, compound 4's estimate is 20.9 percentage points above it; the measured number lies below the stated range.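

Fluoro in place of methoxy does not carry over from one core to the other in this assay: the same change on two cores in this assay, a number 1 percentage points higher (within the scatter) from compound 1 to compound 2 and a number 20.1 percentage points lower (beyond the scatter) from compound 3 to compound 4, 21.1 percentage points apart, beyond the scatter of two such steps

Hydrogen in place of methyl on the oxygen next to the carbonyl group does not carry over either: the same change on two cores in this assay, a number 15.9 percentage points higher (beyond the scatter) from compound 1 to compound 3 and a number 5.2 percentage points lower (within the scatter) from compound 2 to compound 4, 21.1 percentage points apart, beyond the scatter of two such steps

The steps of a number 20.1 percentage points lower from compound 3 to compound 4 (beyond the scatter) and a number 5.2 percentage points lower from compound 2 to compound 4 (within the scatter) show that, among these compounds, the effect of each change depends on the other, so neither can be transferred as a fixed amount; they do not show why, or whether this holds beyond these four compounds.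

The compounds shown leave open how a chloro or an amino group on that aromatic carbon would behave on the core of compound 3. They also leave open whether an amide in place of the carboxylic acid would read like compound 3 or like compound 4.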